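Swapping chlorine for fluorine and cell toxicity

The compounds below may be only part of what the source reports. "The series", "measured", "known", "first", "only" and "open" are said of these compounds alone.

Compound 1 `O=c1oc2ccccc2c(=O)n1-c1ccc(Cl)cc1F` carries a chloro group on its outer ring. In an ADME assay on RAW264.7 cells (Mus musculus) for cytotoxicity, read by MTT assay, with a stated time of 24 h (on this read-out higher numbers stand for lower toxicity in this test and lower numbers for higher toxicity in this test), compound 1 gives 26500 nM. Compound 3 `O=c1oc2ccccc2c(=O)n1-c1ccc(F)cc1F` differs from it by one change, (fluoro in place of chloro on an aromatic carbon). For compound 3 the read-out in this assay is only a limit, > 40000 nM. The step is an at least 1.5-fold higher number from compound 1 to compound 3 (0.17 log units; that floor lies within the scatter), and it rests on (the limit of > 40000 nM in this assay, at which 2 of the 3 values shown sit).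

Compound 2 `O=C(Nc1ccc(Cl)cc1F)c1ccccc1` has a different core; how it differs from the core of compound 1 is not broken down here. For compound 2 the read-out in this assay is again only a limit, > 40000 nM.

Compound 4 `O=C(Nc1ccc(F)cc1F)c1ccccc1` is not yet measured. It stands to compound 2 as compound 3 stands to compound 1, by the same kind of change, (fluoro in place of chloro on an aromatic carbon); around the place, the group para to the changed carbon is here counted as 9 heavy atoms rather than simply called large. A step that the limit leaves unreadable from compound 2 to compound 4 is expected, resting on the earlier step of an at least 1.5-fold higher number from compound 1 to compound 3 (0.17 log units; that floor lies within the scatter) and on the limit of compound 2, > 40000 nM. For compound 4 the estimate in this assay is 50000 nM.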

Compound 4, half-maximal cytotoxic concentration: > 40000 nM
Compound 4: no number, only a limit; the forecaster's own chance of this, stated with the estimate: 80%; the middle value is on the limit's open side.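

In this assay compound 2 and compound 4 both give only a limit, not a number, so no step between them can be read: the limit of > 40000 nM in this assay, at which 3 of the 4 values shown sit.

The compounds shown leave open whether fluoro in place of chloro changes this read-out at all on the core of compound 2.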